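The source may report more compounds than this note shows. Statements on the series, on what has been measured and on what is new or still open speak of the compounds shown alone.

Of the compounds shown here, two sharing one core have been measured in an assay on isolated protein for inhibition of sphingosine 1-phosphate receptor 2 (Homo sapiens), tested at 25 uM; on this read-out higher numbers stand for more inhibition at the one concentration tested (going by the name of the read-out) and lower numbers for less inhibition. Compound 1 `COc1cc(C)c(NC(=O)c2ccc(-c3cc(Cl)ccc3Cl)o2)c(C)c1` gives 70% in this assay. Compound 2 `Cc1ccsc1-c1ccc(C(=O)Nc2c(C)cc(CO)cc2C)o1` gives 90% in this assay, the highest of the two numbers; the nearest, compound 1, lies lower by an amount beyond the usual scatter. Within the data shown here, no pair of measured compounds differs in only one place, so no single-change step is available for comparison.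

Compound 3 `Cc1ccsc1-c1ccc(C(=O)Nc2c(C)cc(O)cc2C)o1` has not yet been measured in this assay. It differs from compound 2 as follows: hydroxy in place of hydroxymethyl on an aromatic carbon. Among the measured compounds shown here, nothing among the measured compounds bears on what a hydroxy in place of a hydroxymethyl on an aromatic carbon does here, so the expectation rests on the level of compound 2 alone. A step in this assay from compound 2 to compound 3 of no more than the usual scatter is expected, if anything a slight fall, since compound 2 already sits high at 90%. For compound 3 the expected value in this assay is 80%, within 55% to 95%. The step from compound 2 to compound 3 is expected to be a number 10 percentage points lower from compound 2 to compound 3 (within the scatter).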

Compound 3, a percentage reported as inhibition, at one concentration (the size of the read-out at that concentration, not a potency): 80%
Beside the measured number, compound 3's estimate shows no gap at the digits printed; measured number inside the range.
By their numbers in this assay, from the lowest: compounds 1, 3 and 2 (each within the scatter of the next, the first and the last beyond it).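

In this assay, among these compounds, hydroxy in place of hydroxymethyl on the aromatic carbon, para to a large group and meta to two methyl groups, gives a number 10 percentage points lower from compound 2 to compound 3 (within the scatter), the first single-change step. At this position, then, the read-out at the one concentration tested does not separate the two groups, so the carbon of the hydroxymethyl can be lost without a change beyond the scatter, while the hydrogen-bond donor and acceptor counts stay the same. No measurement at hand accounts for this step or shows what either group does here.

Still open is whether any oxygen-bearing group is needed at this position, since the compounds shown do not cover a methoxy, an amine, a carboxylic acid or a longer chain such as hydroxyethyl there. Also open is how far the groups at the other end of the molecule matter, as compound 1 and compound 2 differ in more than one place, and a percentage at one concentration gives no potency for any of these compounds.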